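A bromoallyl amide variant of a dienamide inhibitor

The compounds below may be only part of what the source reports. "The series", "measured", "known", "first", "only" and "open" are said of these compounds alone.

Measured compounds in a functional assay on MGC-803 cells (Homo sapiens) for inhibition, read by MTT assay, with a stated time of 48 h; on this read-out higher numbers stand for weaker inhibition and lower numbers for stronger inhibition:
compound 1 `C/C=C/C=C/C(=O)N(Cc1ccc(OC)c(O)c1)c1cc(OC)c(OC)c(OC)c1` gives 140 nM
compound 2 `COc1ccc(CNc2cc(OC)c(OC)c(OC)c2)cc1Br` gives 29400 nM
compound 3 `COC(=O)c1cc(CNc2cc(OC)c(OC)c(OC)c2)ccc1OC` gives 49600 nM

Compound 1 stands lowest of the three, and its gaps to compound 2 and to compound 3 both lie well beyond the scatter, so it is the strongest inhibitor among those measured. Going by the values given here, compound 2 and compound 3 lack the (penta-1,3-dien-1-yl)carbonyl group of compound 1 altogether, and the one recorded step, a 1.7-fold higher number from compound 2 to compound 3 (0.23 log units; within the scatter), concerns a change on an aromatic carbon that has nothing to do with the chain of compound 1. Among the compounds with values here, it therefore carries no weight for the step to compound 4.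

Compound 4 `COc1ccc(CN(C(=O)/C=C/CBr)c2cc(OC)c(OC)c(OC)c2)cc1O` keeps the carbonyl of compound 1 and changes only the chain end: bromomethyl in place of prop-1-en-1-yl on a double-bonded chain carbon bound to a double-bonded chain carbon. Within the data shown here, no measured pair shows such a change, so the expectation rests on the carbonyl chain being kept. A step of a 2.1-fold higher number from compound 1 to compound 4 (0.33 log units; beyond the scatter) in this assay is expected, that is, no change beyond the scatter or a mild weakening. Compound 4 is thus estimated at 300 nM, within a range of 60 nM to 2000 nM.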

Compound 4, half-maximal inhibitory concentration: 71 nM
For compound 4 the middle estimate is 4.2-fold (0.63 log units) above the measured one; the measured number falls inside the stated range.
By their numbers in this assay, from the lowest: compounds 4 and 1 (each within the scatter of the next); then compounds 2 and 3 (each within the scatter of the next).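

In this assay, replacing prop-1-en-1-yl with bromomethyl at this chain end gives a 2.0-fold lower number from compound 1 to compound 4 (0.29 log units; within the scatter), so the two compounds cannot be told apart. This shows that the chain end can change considerably without a measurable loss of inhibition: one double bond outside the aromatic rings leaves, the chain loses a heavy atom overall, and a bromine enters. No independent measurement explains why the two chain ends read alike.

The compounds shown cannot separate any contribution of the bromine from that of the shortened chain, as both changes arrive together in compound 4. Going by these compounds, it remains open how a chloromethyl, a plain methyl or an aminomethyl group would behave on the same double-bonded chain carbon.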